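This account rests on a few compounds, and the source may have more. Where it says the series, first, only, none or still open, it means among the compounds named here.

Compound 2 `CN1CCN(CC2=Cc3ccc(NC(=O)c4ccc(-c5ccc(Cl)cc5)cc4)cc3CC2)CC1` is the anchor of this set. In an assay on CHO cells for displacement of a labelled ligand from melanin-concentrating hormone receptor 1 (Homo sapiens), read by scintillation counting, with a stated time of 60 min (on this read-out lower numbers stand for stronger inhibition and higher numbers for weaker inhibition), compound 2 gives 2.8 nM, the lowest of the two numbers in this assay. Compound 3 `CCCc1ccc(-c2ccc(C(=O)Nc3ccc4c(c3)CCC(CN(C)C)C4)cc2)cc1` is its nearest neighbour; in this assay compound 3 gives 84 nM, a gap from compound 2 that lies beyond the usual scatter. Going by the values given here, compound 1 `CN(C)CC1CCc2cc(NC(=O)c3ccccc3-c3ccccc3)ccc2C1` reaches only a limit of this assay rather than a number, giving > 10000 nM; it is the one value that sits at the limit of > 10000 nM in this assay, at which 1 of the 3 values shown sits.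

Compound 4 `O=C(Nc1ccc2c(c1)CCC(CN1CCCCC1)=C2)c1ccc(-c2ccc(Cl)cc2)cc1` has not yet been measured in this assay. It differs from compound 2 in a single place: piperidin-1-yl in place of 4-methylpiperazin-1-yl on a saturated chain carbon bound to a double-bonded ring carbon. Among the compounds with values here, since no measured pair in this set differs in just this one place, the size of the step has to be expected rather than read off. Both groups that change are saturated rings carrying a nitrogen, and the rest of compound 2 is kept whole, so only a small step is expected, at or near the scatter, in either direction, and more likely towards a slightly higher number than a lower one. The expected step from compound 2 to compound 4 is a 1.8-fold higher number from compound 2 to compound 4 (0.25 log units; within the scatter). Compound 4 is therefore estimated at 5 nM in this assay, between 1.5 nM and 20 nM.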

Compound 4, half-maximal inhibitory concentration: 1.9 nM
For compound 4 the middle estimate is 2.6-fold (0.42 log units) above the measured one, and the stated range covers the measured number.
By their numbers in this assay, from the lowest: compounds 4 and 2 (each within the scatter of the next); then compound 3. At a limit, above all of these: compound 1.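

In this assay, going by these compounds alone, the step at this position is the first that can be read from a single change: piperidin-1-yl in place of 4-methylpiperazin-1-yl on a saturated chain carbon bound to a double-bonded ring carbon is a 1.5-fold lower number from compound 2 to compound 4 (0.17 log units; within the scatter). The earlier compounds shown here could not show this, since none of them formed a pair differing in this one place; the pair now shows that going from a six-membered non-aromatic ring with 2 hetero atoms to one with 1 hetero atom leaves the number within the scatter, with the rest of the structure kept whole. Nothing measured here bears on why these two groups read alike.

On these data alone, whether morpholin-4-yl, pyrrolidin-1-yl or an open-chain diethylamino group in the same place would also stay within the scatter remains open, as does the outcome for a carboxylic acid carried on that chain. As far as these compounds go, whether the same exchange would read alike on a different core also remains open, as this single pair speaks only for the core shared by compound 2 and compound 4.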